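Chain extension from compound 3 to compound 4

This account rests on a few compounds, and the source may have more. Where it says the series, first, only, none or still open, it means among the compounds named here.

Compound 1 (`Cc1[nH]c(=O)n(C)c1-c1ccc(OCCC(C)C)cc1`) gives 6600 nM in a functional assay on brain (Rattus norvegicus, strain Wistar) for inhibition (on this read-out higher numbers stand for weaker inhibition and lower numbers for stronger inhibition), and compound 2 (`CCCCCCOc1ccc(-c2c(C)[nH]c(=O)n2C)cc1`) gives 7300 nM on the same read-out. Compound 3 (`CCCCCCCOc1ccc(-c2c(C)[nH]c(=O)n2C)cc1`) gives 5700 nM here and stands within the scatter of both. All three measured steps are small: a 1.1-fold higher number from compound 1 to compound 2 (0.04 log units; within the scatter), a 1.2-fold lower number from compound 1 to compound 3 (0.06 log units; within the scatter) and a 1.3-fold lower number from compound 2 to compound 3 (0.11 log units; within the scatter) each stay within the scatter. Compound 4 (`CCCCCCCCCCCOc1ccc(-c2c(C)[nH]c(=O)n2C)cc1`) differs from compound 3 by butyl in place of hydrogen on a saturated chain carbon, seven bonds along the chain from an oxygen on an aromatic ring on the chain. For the measured compounds named here, the nearest precedent is the step at almost the same place, a 1.3-fold lower number from compound 2 to compound 3 (0.11 log units; within the scatter), but that step adds only methyl, so butyl in place of hydrogen goes beyond what has been measured. The measured chains therefore give no reason to expect a change beyond the scatter in this assay, and no direction is favoured. The expected step is a 1.0-fold lower number from compound 3 to compound 4 (0.02 log units; within the scatter) on this estimate. Compound 4 is estimated at 5500 nM in this assay. The estimated range for compound 4 runs from 2200 nM to 13000 nM and is kept wide for this untested chain length.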

Compound 4, half-maximal inhibitory concentration: 9700 nM
Estimate against measurement, compound 4: 1.8-fold (0.25 log units) below, within the range that was stated.
By their numbers in this assay, from the lowest: compounds 3, 1, 2 and 4 (each within the scatter of the next).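

Butyl in place of hydrogen on a saturated chain carbon, seven bonds along the chain from an oxygen on an aromatic ring, stays within the scatter in this assay with a 1.7-fold higher number from compound 3 to compound 4 (0.23 log units; within the scatter) as its step. The wider change, pentyl in place of hydrogen six bonds along the chain, gives a 1.3-fold higher number from compound 2 to compound 4 (0.12 log units; within the scatter) and also stays within the scatter, so the chain of compound 4 extends the run of steps without one beyond the scatter. No measured evidence bears on this result.

Going by these compounds, whether an amine or a carboxylic acid on this chain would give a step beyond the scatter remains open. On these data alone, a longer chain than that of compound 4 is equally open, as is any change on the shared core.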